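Shifting a Fluorine: Expected Potency of Compound 4

The compounds below may be only part of what the source reports. "The series", "measured", "known", "first", "only" and "open" are said of these compounds alone.

Compound 1 `Cc1c(C(=O)Nc2ccc(Oc3ccnc4[nH]ccc34)c(F)c2)nnn1-c1ccccc1F` in a functional assay on MCF7 cells (Homo sapiens) for cytotoxicity, read by MTT assay, with a stated time of 72 h; a lower number here means a stronger inhibitor, a higher number a weaker inhibitor: 420 nM
Compound 2 `Cc1c(C(=O)Nc2ccc(Oc3ccnc4[nH]ccc34)c(F)c2)nnn1-c1ccc(F)cc1` in this assay: 170 nM
Compound 3 `O=C(Nc1ccc(Oc2ccnc3[nH]ccc23)cc1)c1nnn(-c2ccccc2F)c1C(F)(F)F` in this assay: 290 nM

Compound 1 and compound 2 share a core and differ by 4-fluorophenyl in place of 2-fluorophenyl on an aromatic nitrogen; the measured step is a 2.5-fold lower number from compound 1 to compound 2 (0.39 log units; beyond the scatter). Compound 3 has a different core, and how it differs from compound 1 is not broken down here; its value and that of compound 1 lie within the usual scatter. Compound 4 `O=C(Nc1ccc(Oc2ccnc3[nH]ccc23)cc1)c1nnn(-c2ccc(F)cc2)c1C(F)(F)F` differs from compound 3 by 4-fluorophenyl in place of 2-fluorophenyl on an aromatic nitrogen. The surroundings are not identical: in compound 1 the ring atom bears a methyl group, in compound 3 a trifluoromethyl group, so this is the same kind of change rather than the same one. Among the compounds with values here, compound 4 is expected to show a 2.2-fold lower number from compound 3 to compound 4 (0.35 log units; beyond the scatter) in this assay, kept somewhat cautious because a 2.5-fold lower number from compound 1 to compound 2 (0.39 log units; beyond the scatter) is the only precedent. Compound 4 is estimated at 130 nM, expected between 60 nM and 300 nM.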

Compound 4, half-maximal inhibitory concentration: 210 nM
The estimate for compound 4 lay 1.6-fold (0.21 log units) below the measured number, within the range that was stated.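

In this assay, 4-fluorophenyl in place of 2-fluorophenyl on the aromatic nitrogen gives a 1.4-fold lower number from compound 3 to compound 4 (0.14 log units; within the scatter), so on this core the change cannot be told apart from repeat measurement. Set beside the earlier step, the result does not differ from it: the same change on two cores in this assay, a 2.5-fold lower number (0.39 log units; beyond the scatter) from compound 1 to compound 2 and a 1.4-fold lower number (0.14 log units; within the scatter) from compound 3 to compound 4, 1.8-fold (0.25 log units) apart, within the scatter of two such steps. This is compatible with the change carrying over between the two cores, but it does not prove that it does: one of the two steps lies within the scatter, and two pairs make no rule for the series.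

The compounds shown leave open whether the change behaves alike with an ethyl group or a nitrile in place of the methyl or trifluoromethyl group. They also leave open how an amine or a carboxylic acid on the phenyl ring would read in this assay.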